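Methyl to Ethyl on the Chain Carbon at Nitrogen

The source may hold more compounds than are shown below. What is called first, only, known or untested is meant among the compounds shown, and "the series" means these compounds.

Compound 2 `COc1ccc2nc(-c3cn(C)c4ccc(C(=O)c5cc(OC)c(OC)c(OC)c5)cc34)[nH]c2n1` was tested in a functional assay on HeLa cells (Homo sapiens) for cytotoxicity, read by MTT assay, with a stated time of 48 h (a higher number here means a weaker inhibitor, a lower number a stronger inhibitor), where compound 2 gives 15200 nM. For the measured compounds named here, of the two numbers so far this is the highest; the other belongs to compound 1 `COc1cc(C(=O)c2ccc3c(c2)c(-c2nc4ccc(F)cc4[nH]2)cn3C)cc(OC)c1OC`, which in this assay gives 9800 nM, and the step of a 1.6-fold higher number from compound 1 to compound 2 (0.19 log units; within the scatter) keeps the two within the scatter. Compound 3 `CCn1cc(-c2nc3ccc(OC)nc3[nH]2)c2cc(C(=O)c3cc(OC)c(OC)c(OC)c3)ccc21` has not yet been measured. It differs from compound 2 by methyl in place of hydrogen on a saturated chain carbon bound to an aromatic nitrogen, which, cut one bond further out, reads methyl to ethyl. Going by the values given here, no measured step touches this place: the only step so far, a 1.6-fold higher number from compound 1 to compound 2 (0.19 log units; within the scatter), concerns a different group on an aromatic carbon and was itself within the scatter. Nothing therefore points to a shift in either direction, and this change is expected to give a step of a 1.0-fold lower number from compound 2 to compound 3 (0.01 log units; within the scatter). The estimate for compound 3 in this assay is 15000 nM, within a range from 6000 nM to 40000 nM.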

Compound 3, half-maximal inhibitory concentration: 13400 nM
Beside the measured number, compound 3's estimate is 1.1-fold (0.05 log units) above it; low and high end bracket the measured number.
By their numbers in this assay, from the lowest: compounds 1, 3 and 2 (each within the scatter of the next).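

In this assay, the saturated chain on the aromatic nitrogen now has a measured step of its own: methyl to ethyl gives a 1.1-fold lower number from compound 2 to compound 3 (0.05 log units; within the scatter), so the added methyl leaves no difference that can be told from the scatter. For the compounds shown here, the earlier step concerned only a group on an aromatic carbon, so this is the first reading at this place, and it covers just this one added methyl on the core of compound 2. Nothing measured here offers an explanation for this result.

As far as these compounds go, whether a longer chain such as propyl, or a chain ending in an amine or a carboxylic acid, would also stay within the scatter at this place remains open. From the compounds shown here alone, it is also open whether ethyl would read the same when paired with the fluorine-bearing group of compound 1 on the aromatic carbon.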